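Oxazole in place of the amide on the shared core

The compounds below may be only part of what the source reports. "The series", "measured", "known", "first", "only" and "open" are said of these compounds alone.

Compound 1 `CCCOC(=O)C1=C(C)NC(=O)NC1c1ccoc1` gives 11% in an assay on membranes from HeLa cells for displacement of a labelled ligand from adenosine receptor A3 (Homo sapiens), read by scintillation counting, with a stated time of 180 min, tested at 1 uM; on this read-out lower numbers stand for less inhibition and higher numbers for more inhibition at the one concentration tested (going by the name of the read-out). Compound 2 `CC1=C(C(=O)NC(C)C)C(c2ccoc2)NC(=O)N1` gives 3% in this assay; the step of a number 8 percentage points lower from compound 1 to compound 2 (within the scatter) stays within the scatter, so on the two numbers compound 2 is the lower only nominally, with compound 1 its nearest neighbour within the scatter. Among the compounds with values here, compound 3 `CC1=C(c2ncc(C)o2)C(c2ccoc2)NC(=O)N1` is still to be measured. 5-methyl-1,3-oxazol-2-yl in place of isopropylcarbamoyl on a double-bonded ring carbon The only measured step, isopropylamino in place of propoxy on a carbonyl carbon, moved the read-out within the scatter, and no measured step replaces the carbonyl group by an aromatic ring at this place, so nothing beyond the scatter is expected here either. Compound 3 is expected to give 8% in this assay, within a range from -6% to 24%. The step of a number 5 percentage points higher from compound 2 to compound 3 (within the scatter) is estimated to remain inside the scatter.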

Compound 3, a percentage reported as inhibition, at one concentration (the size of the read-out at that concentration, not a potency): 1%
Beside the measured number, compound 3's estimate is 7 percentage points above it, and the stated range covers the measured number.
By their numbers in this assay, from the lowest: compounds 3, 2 and 1 (each within the scatter of the next).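

In this assay, 5-methyl-1,3-oxazol-2-yl in place of isopropylcarbamoyl on the double-bonded ring carbon gives a number 2 percentage points lower from compound 2 to compound 3 (within the scatter) and so adds an aromatic ring at this position without a change beyond the scatter. Set against the propoxycarbonyl group, the same ring gives a number 10 percentage points lower from compound 1 to compound 3 (within the scatter), so the ester, the amide and the oxazole cannot be told apart at this position on this read-out. No supporting data bear on this result, and it stands without an explanation.

The compounds shown leave open whether any group at this position moves the read-out beyond the scatter, for instance a carboxylic acid, a primary amine or a longer alkoxycarbonyl chain. They also leave open whether a change at the furan-3-yl group or the methyl group would do so.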